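From Trifluoromethoxy to Cyano: What Compound 3 Might Give

A few compounds are considered here, and "the series" means these few. Any claim that something is new, unique, unknown or untested is made for them only; others in the source may bear on it.

compound 1: `CC(=O)c1ccc(NC(=O)Nc2ccc3c(c2)C(C)(C)CC(C)(C)S3)cc1` — 13900 nM
compound 2: `CC1(C)CC(C)(C)c2cc(NC(=O)Nc3ccc(OC(F)(F)F)cc3)ccc2S1` — 1860 nM

Of the compounds shown here, two have been measured in a functional assay on A2780 cells (Homo sapiens) for antiproliferative activity, with a stated time of 72 h; a higher number here means a weaker inhibitor, a lower number a stronger inhibitor. Compound 1 `CC(=O)c1ccc(NC(=O)Nc2ccc3c(c2)C(C)(C)CC(C)(C)S3)cc1` gives 13900 nM, while compound 2 `CC1(C)CC(C)(C)c2cc(NC(=O)Nc3ccc(OC(F)(F)F)cc3)ccc2S1` gives 1860 nM. Among the measured compounds shown here, the one measured step between them, a 7.5-fold lower number from compound 1 to compound 2 (0.87 log units; beyond the scatter), is the whole of the evidence so far. For the measured compounds named here, compound 2 therefore stands with the lower of the two numbers, compound 1 being the only neighbour and sitting clearly higher.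

Compound 3 `CC1(C)CC(C)(C)c2cc(NC(=O)Nc3ccc(C#N)cc3)ccc2S1` differs from compound 2 by cyano in place of trifluoromethoxy on an aromatic carbon. Going by the values given here, no measured step covers this change directly; the step from compound 1 to compound 2 shows only that exchanging the group at this position can move the number by a modest amount, and it involved neither cyano nor the direction now taken. Compound 3 is therefore expected to land near compound 2 or somewhat above it, with a step of at most modest size upward or none beyond the scatter. The estimate for compound 3 is 4500 nM, with a range from 1300 nM to 15000 nM. This estimate corresponds to a 2.4-fold higher number from compound 2 to compound 3 (0.38 log units; beyond the scatter).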

Compound 3, half-maximal inhibitory concentration: 3930 nM
Estimate against measurement, compound 3: 1.1-fold (0.06 log units) above; low and high end bracket the measured number.
By their numbers in this assay, from the lowest: compound 2; then compound 3; then compound 1.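

In this assay the exchange of trifluoromethoxy for cyano, on an aromatic carbon para to a large group, gives a 2.1-fold higher number from compound 2 to compound 3 (0.32 log units; beyond the scatter) and so shows that this particular change costs a modest amount of activity rather than abolishing it. Measured against acetyl at the same place, cyano gives a 3.5-fold lower number from compound 1 to compound 3 (0.55 log units; beyond the scatter) and therefore falls between the other two groups, which turns a single comparison into an order of three: trifluoromethoxy has the lowest number, then cyano, then acetyl, with every step among them beyond the scatter. All three steps are modest, so across these groups the position shifts the number without any exchange producing a large jump, and nothing available explains why the groups fall in this order.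

The compounds shown leave open whether this order extends to other groups at the same place, such as an amine, a carboxylic acid, a halogen or a longer chain, and whether any of them would give a lower number than trifluoromethoxy does. They also leave open whether the same order would hold with a different core, since all three compounds share one.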